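The compounds below may be only part of what the source reports. "The series", "measured", "known", "first", "only" and "open" are said of these compounds alone.

Measured compounds:
compound 1 `CN(C)CCCCCSC1=Nc2ccccc2C(CC(=O)NCc2ccc(F)cc2)N1c1ccc(-c2ccccc2)cc1` — 27400 nM
compound 2 `O=C(CC1c2ccccc2N=C(SCCCCCN2CCCC2)N1c1ccc(-c2ccccc2)cc1)NCc1ccc(F)cc1` — 15000 nM

Of the compounds shown here, two have been measured in an assay on cells for inhibition of Voltage-dependent T-type calcium channel subunit alpha-1G (Homo sapiens), read by patch clamp; a lower number here means a stronger inhibitor, a higher number a weaker inhibitor. Among the compounds with values here, compound 2 gives 15000 nM, the lower of the two numbers, but the single measured step, a 1.8-fold lower number from compound 1 to compound 2 (0.26 log units; within the scatter), is within the scatter, so compound 2 and compound 1 cannot be told apart on these data.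

Compound 3 `O=C(CC1c2ccccc2N=C(SCCCCCN2CCCC2)N1c1ccc(-c2ccccc2)cc1)NCc1ccccc1` differs from compound 2 at the far end of the molecule: hydrogen in place of fluoro on an aromatic carbon. Within the data shown here, the one measured step concerns the amine at the end of the chain, not the benzyl amide, so no measured step bears on this change. Nothing in the data points to a shift beyond the scatter in either direction, and the estimate for compound 3 therefore stays near compound 2 at 18000 nM, with a range of 6000 nM to 50000 nM. The expected step is a 1.2-fold higher number from compound 2 to compound 3 (0.08 log units; within the scatter).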

Compound 3, half-maximal inhibitory concentration: 660 nM
The estimate for compound 3 lay 27-fold (1.44 log units) above the measured number; measured number outside the range, below it.
By their numbers in this assay, from the lowest: compound 3; then compounds 2 and 1 (each within the scatter of the next).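

In this assay, within the data shown here, the change from 4-fluorobenzyl to benzyl on the amide gives the first step beyond the scatter (a 23-fold lower number from compound 2 to compound 3 (1.36 log units; beyond the scatter)). The exchange of dimethylamino for pyrrolidin-1-yl at the other end of the molecule stayed within the scatter (a 1.8-fold lower number from compound 1 to compound 2 (0.26 log units; within the scatter)), so among these compounds it is this aromatic carbon, carrying hydrogen rather than fluoro, where a single-atom change separates two numbers. Nothing available explains why the loss of this one atom has so large an effect.

The compounds shown leave open whether chloro, methyl or methoxy on the same aromatic carbon would give a number closer to that of compound 2 or compound 3. They also leave open whether dimethylamino or a longer chain at the amine end would change the number once the benzyl amide is in place.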